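This account rests on a few compounds, and the source may have more. Where it says the series, first, only, none or still open, it means among the compounds named here.

Working notes on the series. In a functional assay on RS4-11 cells (Homo sapiens) for inhibition, read by CCK-8 assay, with a stated time of 48 h (a lower number here means a stronger inhibitor, a higher number a weaker inhibitor), compound 2, `O=C(NCCNS(=O)(=O)c1ccc(-c2ccccc2Oc2ccc([N+](=O)[O-])c([N+](=O)[O-])c2)s1)Nc1cc(C(F)(F)F)cc(C(F)(F)F)c1`, gives 2400 nM, the highest of the two numbers recorded in this assay. Compound 3, `O=[N+]([O-])c1ccc(NC(=S)NCCNS(=O)(=O)c2ccc(-c3ccccc3O[C@H]3CC[C@H](O)CC3)s2)cc1`, gives 1500 nM, a gap that sits within the scatter, so the two are not ordered. Compound 1, `COc1cccc(NC(=S)NCCNS(=O)(=O)c2ccc(-c3ccccc3Oc3ccc([N+](=O)[O-])cc3)s2)c1`, returns only a limit, > 50000 nM, so the limit of > 50000 nM in this assay, at which 1 of the 3 values shown sits, gives no number for it. Compound 4, `O=C(NCCNS(=O)(=O)c1ccc(-c2ccccc2O[C@H]2CC[C@H](O)CC2)s1)Nc1cc(C(F)(F)F)cc(C(F)(F)F)c1`, is not yet measured; it differs from compound 2 by 4-hydroxycyclohexyl in place of 3,4-dinitrophenyl on an oxygen on an aromatic ring. Among the measured compounds shown here, no measured pair isolates this change, so no step can be read off. Compound 3 carries the same 4-hydroxycyclohexyl group and gives 1500 nM, which suggests the change from compound 2 is expected to fall within the scatter, a 1.3-fold lower number from compound 2 to compound 4 (0.12 log units; within the scatter). Compound 4 is therefore estimated at 1800 nM, with a range from 600 nM to 6000 nM.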

Compound 4, half-maximal inhibitory concentration: 10100 nM
Compound 4: the middle estimate sits 5.6-fold (0.75 log units) below what was measured; the whole stated range lies below it.
By their numbers in this assay, from the lowest: compounds 3 and 2 (each within the scatter of the next); then compound 4. At a limit, above all of these: compound 1.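

In this assay the change to 4-hydroxycyclohexyl in place of 3,4-dinitrophenyl on an oxygen on an aromatic ring gives a 4.2-fold higher number from compound 2 to compound 4 (0.62 log units; beyond the scatter) with the rest of the molecule held fixed. Among the compounds shown here, this is the first reading of this position that isolates the change, and the lower number lies with the 3,4-dinitrophenyl group. Nothing measured here accounts for the step.

Still open, going by these compounds, is where an unsubstituted phenyl, an aminophenyl or a cyclohexyl without the hydroxyl would fall on that oxygen. Also open, on these data alone, is whether the step carries over to the thiourea of compound 3.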